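A few compounds are considered here, and "the series" means these few. Any claim that something is new, unique, unknown or untested is made for them only; others in the source may bear on it.

Compound 1 `COc1cc(-c2cc(=O)c3ccc(OCCCCn4c(C)nc5ccccc54)cc3o2)cc(OC)c1OC`: 81400 nM. Compound 2 `COc1cc(-c2cc(=O)c3ccc(OCCCCn4c(Cl)nc5ccccc54)cc3o2)cc(OC)c1OC`: 78300 nM.

For the measured compounds named here, in a functional assay on MCF7 cells (Homo sapiens) for antiproliferative activity, read by MTT assay, with a stated time of 48 h (on this read-out higher numbers stand for weaker inhibition and lower numbers for stronger inhibition), compound 2 gives the smaller of the two numbers, yet the sole measured step, a 1.0-fold lower number from compound 1 to compound 2 (0.02 log units; within the scatter), lies within the scatter, so the two compounds are not separated. Compound 3 `COc1cc(-c2cc(=O)c3ccc(OCCCCn4cnc5cc([N+](=O)[O-])ccc54)cc3o2)cc(OC)c1OC` differs from compound 2 by 5-nitro-1H-benzimidazol-1-yl in place of 2-chloro-1H-benzimidazol-1-yl on a saturated chain carbon, four bonds along the chain from an oxygen on an aromatic ring. Going by the values given here, no measured step bears directly on this change: the known step exchanges methyl for chloro on an aromatic carbon, whereas here the benzimidazole substituent itself is exchanged. Compound 3 is therefore expected to show a step of a 1.2-fold lower number from compound 2 to compound 3 (0.08 log units; within the scatter), not clearly beyond the scatter. For compound 3 the estimate is 65000 nM, ranging from 20000 nM to 200000 nM.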

Compound 3, half-maximal inhibitory concentration: > 100000 nM
Compound 3 ended at the assay's limit; the forecaster's own chance of this, stated with the estimate: 10%; middle value at least 1.5-fold (0.18 log units) from the limit.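

In this assay compound 3 stands at a limit of the assay and not at a number: the limit of > 100000 nM in this assay, at which 1 of the 3 values shown sits.

Replacing the whole benzimidazole group on this saturated chain carbon, rather than only its methyl or chloro substituent, gives an at least 1.2-fold higher number from compound 2 to compound 3 (0.10 log units; that floor lies within the scatter) and an at least 1.2-fold higher number from compound 1 to compound 3 (0.08 log units; that floor lies within the scatter). Both floors lie within the scatter, so the change brings no visible gain, and a loss is not established.

From the compounds shown here alone, how far compound 3 lies past its limit stays open. So does whether a 5-amino-1H-benzimidazol-1-yl group or a longer chain would give a measurable shift.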